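Lengthening the Amine Chain on a Benzhydryl Ether Piperidine

The compounds below may be only part of what the source reports. "The series", "measured", "known", "first", "only" and "open" are said of these compounds alone.

Three compounds share one core and differ only in the chain carried on the ring nitrogen. Compound 1 `CCCCCN1CCC(COC(c2ccccc2)c2ccccc2)CC1` gives 10800 nM in a functional assay on cells (T-cell line, Homo sapiens) for inhibition; on this read-out lower numbers stand for stronger inhibition and higher numbers for weaker inhibition. Compound 2 `CCCCCCN1CCC(COC(c2ccccc2)c2ccccc2)CC1` gives 5500 nM in this assay, and compound 3 `CCCCCCCCN1CCC(COC(c2ccccc2)c2ccccc2)CC1` gives 700 nM in this assay.

Compound 2 differs from compound 1 by methyl in place of hydrogen on a saturated chain carbon, five bonds along the chain from an amine nitrogen in a ring, and this produced a 2.0-fold lower number from compound 1 to compound 2 (0.29 log units; within the scatter). Compound 3 differs from compound 1 by propyl in place of hydrogen on a saturated chain carbon, five bonds along the chain from an amine nitrogen in a ring, giving a 15-fold lower number from compound 1 to compound 3 (1.19 log units; beyond the scatter). Compound 3 differs from compound 2 by ethyl in place of hydrogen, and the result was a 7.9-fold lower number from compound 2 to compound 3 (0.90 log units; beyond the scatter). Among these three, compound 3 shows the lowest number, and its steps to both others lie beyond the scatter.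

Compound 4 `CCCCCCCCCN1CCC(COC(c2ccccc2)c2ccccc2)CC1` has not been measured. It differs from compound 3 by methyl in place of hydrogen on a saturated chain carbon, eight bonds along the chain from an amine nitrogen in a ring. This is the same kind of change as that from compound 1 to compound 2, but not the same one: there the methyl entered five bonds along the chain from the amine nitrogen, here eight bonds along it. Across the three measured compounds each added chain carbon went with a lower number, so a further lowering is expected for compound 4, though a smaller one than the step to compound 3, since the sequence may level off; the expected step is a 2.0-fold lower number from compound 3 to compound 4 (0.30 log units; within the scatter). Compound 4 is estimated at 350 nM, with a likely range from 120 nM to 1000 nM.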

Compound 4, half-maximal inhibitory concentration: 700 nM
Compound 4: middle estimate off by 2.0-fold (0.30 log units), on the low side; the measured number falls inside the stated range.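

In this assay, among these compounds, methyl in place of hydrogen eight bonds along the chain gave no change at the digits printed from compound 3 to compound 4 (within the scatter), and set beside the earlier methyl step, the two do not separate: the same change on two cores in this assay, a 2.0-fold lower number (0.29 log units; within the scatter) from compound 1 to compound 2 and no change at the digits printed (within the scatter) from compound 3 to compound 4, 2.0-fold (0.29 log units) apart, within the scatter of two such steps The larger additions point the same way, with propyl giving a 7.9-fold lower number from compound 2 to compound 4 (0.90 log units; beyond the scatter) and butyl giving a 15-fold lower number from compound 1 to compound 4 (1.19 log units; beyond the scatter), and the propyl step stands close to the earlier one: the same change on two cores in this assay, a 15-fold lower number (1.19 log units; beyond the scatter) from compound 1 to compound 3 and a 7.9-fold lower number (0.90 log units; beyond the scatter) from compound 2 to compound 4, 2.0-fold (0.29 log units) apart, within the scatter of two such steps These two comparisons show that, for these chains on the ring nitrogen, a given addition gave steps of similar size at different starting lengths, but they rest on only two pairs of steps, and they do not show that the same change would carry to a different core or that compound 3 and compound 4 can be ordered.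

From the compounds shown here alone, what remains open is whether a chain longer than that of compound 4 would leave the number unchanged, lower it or raise it. Also open is how a chain ending in a hydroxyl group or an amine would compare with the plain chains shown here.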